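The source may hold more compounds than are shown below. What is called first, only, known or untested is meant among the compounds shown, and "the series" means these compounds.

Three compounds share one core and differ only in the group attached to the amide nitrogen. Among the measured compounds shown here, compound 1 `COc1ccc(CNC(=O)c2nc(Br)c3cccnc3c2N[C@H]2CC[C@H](N)CC2)cc1` is the sole measured member: in a functional assay on HCT-116 cells (Homo sapiens) for cytotoxicity, read by MTT assay, with a stated time of 72 h (on this read-out higher numbers stand for weaker inhibition and lower numbers for stronger inhibition), compound 1 gives 3000 nM. For the measured compounds named here, compound 2 `CN(C)c1ccc(CNC(=O)c2nc(Br)c3cccnc3c2N[C@H]2CC[C@H](N)CC2)cc1` was run in the same series, but in this assay compound 2 is recorded as "not determined" (no result reported), so no number stands for it and no measured pair is available in the set. Compound 3 `C[C@H](NC(=O)c1nc(Br)c2cccnc2c1N[C@H]1CC[C@H](N)CC1)c1ccc(F)cc1` follows from compound 2 by one change: 1-(4-fluorophenyl)ethyl in place of 4-(dimethylamino)benzyl on an amide-type nitrogen. Going by the values given here, with compound 2 unmeasured, the only anchor is compound 1, whose value sits in the low micromolar range; the direction of the step in this assay cannot be read from any measured pair, and no shift beyond the usual scatter is assumed. For compound 3 the value in this assay is estimated at 3000 nM, expected to fall between 800 nM and 12000 nM.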

Compound 3, half-maximal inhibitory concentration: > 10000 nM
Compound 3 ended at the assay's limit (the forecaster's own chance of this, stated with the estimate: 10%); at least 3.3-fold (0.52 log units) between middle value and limit.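

In this assay, the group on the amide-type nitrogen proves not to be indifferent: 1-(4-fluorophenyl)ethyl in place of 4-methoxybenzyl gives an at least 3.3-fold higher number from compound 1 to compound 3 (0.52 log units; beyond the scatter), a move toward weaker inhibition that a single measured value could not show. Compound 3 gives > 10000 nM, which is a limit of the assay and not a number. The size of the step is therefore only a bound, and the true gap stays unknown: the limit of > 10000 nM in this assay, at which 1 of the 3 values shown sits.

The step involving compound 2 cannot be read, and the change from compound 1 to compound 3 alters the para-free naming of neither part separately: the ring substituent and the defined stereocentre change together. A 4-fluorobenzyl group on the same nitrogen would separate the fluorine from the branching, and the shown compounds leave that split open.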